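Swapping the benzyl halogens in a hydroxamate sulfonamide series

A few compounds are considered here, and "the series" means these few. Any claim that something is new, unique, unknown or untested is made for them only; others in the source may bear on it.

The measured compounds, with their numbers in an assay on isolated protein for inhibition of bone morphogenetic protein 1 (Homo sapiens); on this read-out higher numbers stand for weaker inhibition and lower numbers for stronger inhibition:
Compound 1 `COc1ccc(S(=O)(=O)N(Cc2cc(C)on2)[C@H](C)C(=O)NO)cc1` gives 230 nM in this assay.
Compound 2 `COc1ccc(S(=O)(=O)N(Cc2cccc(Br)c2)[C@H](C)C(=O)NO)cc1` gives 93 nM in this assay.
Compound 3 `COc1ccc(S(=O)(=O)N(Cc2ccc(Cl)c(Cl)c2)[C@H](C)C(=O)NO)cc1` gives 120 nM in this assay.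

Compound 3 holds the second highest of the three numbers; its gap to compound 2 and its gap to compound 1 both lie within the scatter, so no order among these three can be read from this assay beyond the step of a 2.5-fold lower number from compound 1 to compound 2 (0.39 log units; beyond the scatter), which is the only one that stands clear of it.

Compound 4 `COc1ccc(S(=O)(=O)N(Cc2cc(F)cc(F)c2)[C@H](C)C(=O)NO)cc1` differs from compound 3 in one place: 3,5-difluorophenyl in place of 3,4-dichlorophenyl on a saturated chain carbon bound to a sulfonamide nitrogen. Going by the values given here, the steps that bear on this change are those that swap one aryl or heteroaryl group for another on the same carbon. Both measured aryl groups sit close together: a 1.3-fold higher number from compound 2 to compound 3 (0.11 log units; within the scatter), while a 1.9-fold lower number from compound 1 to compound 3 (0.28 log units; within the scatter) and a 2.5-fold lower number from compound 1 to compound 2 (0.39 log units; beyond the scatter) describe what a change away from the methyl-oxazole did. A move between two halogenated phenyl groups has so far produced only a step within the scatter. For compound 4, therefore, the expected step is a 1.3-fold higher number from compound 3 to compound 4 (0.10 log units; within the scatter), that is, no change beyond the scatter. Compound 4 is estimated to give about 150 nM in this assay, with a range from 70 nM to 330 nM.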

Compound 4, half-maximal inhibitory concentration: 140 nM
For compound 4 the middle estimate is 1.1-fold (0.03 log units) above the measured one, within the range that was stated.
By their numbers in this assay, from the lowest: compounds 2, 3, 4 and 1 (each within the scatter of the next, the first and the last beyond it).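

In this assay, the 3,5-difluorophenyl in place of the 3,4-dichlorophenyl (a 1.2-fold higher number from compound 3 to compound 4 (0.07 log units; within the scatter)) and in place of the 3-bromophenyl (a 1.5-fold higher number from compound 2 to compound 4 (0.18 log units; within the scatter)) left every step among the three halogenated phenyl groups within the scatter, so this position on a saturated chain carbon bound to a sulfonamide nitrogen has now taken fluorine, chlorine and bromine in different substitution patterns with no readable difference. The step away from the 5-methyl-1,2-oxazol-3-yl to the 3,5-difluorophenyl (a 1.6-fold lower number from compound 1 to compound 4 (0.22 log units; within the scatter)) also stays within the scatter, unlike the one to the 3-bromophenyl (a 2.5-fold lower number from compound 1 to compound 2 (0.39 log units; beyond the scatter)), so leaving the methyl-oxazole for a halogenated phenyl group does not by itself give a step that clears the scatter. No available evidence bears on why these groups sit so close together.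

The compounds shown leave open whether a halogen is needed at all, as a plain phenyl is not among them. They also leave open how this position would respond to a phenyl carrying an amine or a carboxylic acid, or to a longer chain between the sulfonamide nitrogen and the ring.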